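The source may hold more compounds than are shown below. What is called first, only, known or untested is meant among the compounds shown, and "the series" means these compounds.

Working notes on the series. All three measured compounds carry the shared core of compound 1 `COc1ncc(-c2ccc3c(c2)N(c2ccc(C)cc2)C(=O)CO3)cc1NS(=O)(=O)c1ccc(F)cc1`, tested in a functional assay on MCF7 cells (Homo sapiens) for antiproliferative activity, read by MTT assay, with a stated time of 72 h; on this read-out higher numbers stand for weaker inhibition and lower numbers for stronger inhibition. Compound 1 gives 15400 nM, the lowest of the two numbers available. Compound 3 `O=C1COc2ccc(-c3cnc(Cl)c(NS(=O)(=O)c4ccc(F)cc4)c3)cc2N1c1ccc(Cl)cc1` gives 32800 nM, a higher number, beyond the scatter. Compound 2 `COc1ccc(N2C(=O)COc3ccc(-c4cnc5ccccc5c4)cc32)cc1` reaches only a limit of the assay, > 40000 nM; this is the limit noted in the limit of > 40000 nM in this assay, at which 1 of the 3 values shown sits. Compound 4 `COc1ncc(-c2ccc3c(c2)N(C(C)C)C(=O)CO3)cc1NS(=O)(=O)c1ccc(F)cc1` is not yet measured. It differs from compound 1 by isopropyl in place of 4-methylphenyl on an amide-type nitrogen in a ring, isopropyl replacing 4-methylphenyl on the amide-type nitrogen in the ring. Going by the values given here, no measured step of this kind exists among the compounds, so the expectation rests on the weak activity seen across the series. Compound 4 is expected to give about 25000 nM, estimated between 8000 nM and 70000 nM, an expected step of a 1.6-fold higher number from compound 1 to compound 4 (0.21 log units; within the scatter) toward a somewhat higher number.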

Compound 4, half-maximal inhibitory concentration: 17000 nM
Compound 4: middle estimate off by 1.5-fold (0.17 log units), on the high side; the range from low to high includes it.
By their numbers in this assay, from the lowest: compounds 1, 4 and 3 (each within the scatter of the next, the first and the last beyond it). At a limit, above all of these: compound 2.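

In this assay, isopropyl in place of 4-methylphenyl on the amide-type nitrogen in the ring gives a 1.1-fold higher number from compound 1 to compound 4 (0.04 log units; within the scatter). This first step at this position shows that the six-membered aromatic ring of 4-methylphenyl is not required to keep the activity of compound 1, since isopropyl, with no ring, stays within the scatter of it. Nothing in the data shown gives a reason for this step. Open, going by these compounds, is how this position responds to a group of another kind, such as an amine or a carboxylic acid on a longer chain. Also open, on these data alone, is whether any group here gives clearly stronger inhibition than compound 1.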